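This account rests on a few compounds, and the source may have more. Where it says the series, first, only, none or still open, it means among the compounds named here.

Among the compounds with values here, in a physicochemical assay for solubility, read by HPLC, in phosphate buffer, measured as kinetic solubility, at pH 7.4 (a higher number here means a more soluble compound, a lower number a less soluble compound), compound 1 (`CCC(=O)c1cc(-c2ccc(F)cc2)n(-c2ccc(S(N)(=O)=O)cc2)c1C`) gives 29300 nM and compound 2 (`CCOC(=O)c1cc(-c2ccc(F)cc2)n(-c2ccc(S(N)(=O)=O)cc2)c1C`) gives 12600 nM, the lower of the two numbers so far. Compound 3 (`Cc1c(C(=O)O)cc(-c2ccc(F)cc2)n1-c1ccc(S(N)(=O)=O)cc1`) is the next to be read, and its difference from compound 2 is counted as hydrogen in place of ethyl on an oxygen next to a carbonyl group. Hydrogen stands in place of ethyl on an oxygen next to a carbonyl group, which reads equally as ethoxycarbonyl to carboxy.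

Within the data shown here, only one measured step bears on this: a 2.3-fold lower number from compound 1 to compound 2 (0.37 log units; beyond the scatter), a modest step with ethoxy in place of ethyl on a carbonyl carbon. Among the measured compounds shown here, no measured compound carries a carboxy group, so that step is a loose guide, and the direction rests on the structural change alone. A move to a higher number in this assay is expected, larger than the modest step seen with compound 2 at 12600 nM. The expected step is a 7.9-fold higher number from compound 2 to compound 3 (0.90 log units; beyond the scatter). For compound 3 the estimated value is 100000 nM, with an estimated range from 30000 nM to 300000 nM.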

Compound 3, solubility: 50000 nM
The estimate for compound 3 lay 2.0-fold (0.30 log units) above the measured number; the range from low to high includes it.
By their numbers in this assay, from the lowest: compound 2; then compounds 1 and 3 (each within the scatter of the next).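

In this assay, hydrogen in place of ethyl on an oxygen next to a carbonyl group gives a 4.0-fold higher number from compound 2 to compound 3 (0.60 log units; beyond the scatter), a step that runs opposite in direction to a 2.3-fold lower number from compound 1 to compound 2 (0.37 log units; beyond the scatter) and shows that this position can move the number both ways. The remaining step is a 1.7-fold higher number from compound 1 to compound 3 (0.23 log units; within the scatter), so compound 1 and compound 3 cannot be told apart here, while compound 2 stands apart from both, with its steps to each printed as beyond the scatter. No measurement at hand gives a reason for any of these steps.

Open, on these data alone, is whether a carbonyl carbon bearing an amino group, as in a primary amide, would read with compound 1 and compound 3 or with compound 2. Also open, as far as these compounds go, is whether a longer chain such as butyl on the oxygen next to a carbonyl group would extend the step seen between ethyl and hydrogen or leave the number within the scatter of compound 2.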